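From tert-Butyl to Neopentyl in Compound 4

A few compounds are considered here, and "the series" means these few. Any claim that something is new, unique, unknown or untested is made for them only; others in the source may bear on it.

In an ADME assay on Caco-2 cells (Homo sapiens) for permeability, read by LC-MS, in the apical to basolateral direction, with a stated time of 60 min, at pH 6.5 (a higher number here means that the compound crosses the layer faster, a lower number that the compound crosses the layer more slowly), compound 1 (`CC(C)(C)[C@@H](O)C(=O)N1C[C@@H]2C[C@@H]2[C@H]1C(=O)NCc1cc(Cl)ccc1-n1cnnn1`) gives 17 10^-6 cm/s. Compound 3 (`O=C(NCc1cc(Cl)ccc1-n1cnnn1)[C@@H]1C[C@H]2C[C@H]2N1C(=O)[C@H](O)c1ccccc1`) gives 17 10^-6 cm/s, level with compound 1, and the two together hold the top of the three numbers. Compound 2 (`CC(C)(C)[C@@H](O)C(=O)N1CSC(C)(C)[C@H]1C(=O)NCc1cc(Cl)ccc1-n1cnnn1`) gives 6.2 10^-6 cm/s, the furthest from compound 1 and beyond the usual scatter.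

Compound 4 (`CC(C)(C)C[C@@H](O)C(=O)N1C[C@@H]2C[C@@H]2[C@H]1C(=O)NCc1cc(Cl)ccc1-n1cnnn1`) departs from compound 1 in one place: neopentyl in place of tert-butyl on a saturated chain carbon bound to a carbonyl carbon and an oxygen on a saturated carbon. For the measured compounds named here, no measured pair isolates a single change, so the expectation in this assay is loose. The estimated move is small and stays within the scatter, a 1.1-fold lower number from compound 1 to compound 4 (0.05 log units; within the scatter). For compound 4 the expected number is 15 10^-6 cm/s, with an estimated range of 7 10^-6 cm/s to 30 10^-6 cm/s.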

Compound 4, apparent permeability: 25 10^-6 cm/s
Beside the measured number, compound 4's estimate is 1.7-fold (0.22 log units) below it; low and high end bracket the measured number.
By their numbers in this assay, from the lowest: compound 2; then compounds 1, 3 and 4 (each within the scatter of the next).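

Neopentyl in place of tert-butyl on a saturated chain carbon bound to a carbonyl carbon and an oxygen on a saturated carbon is the first single-place change that can be read in this assay, and the step is a 1.5-fold higher number from compound 1 to compound 4 (0.17 log units; within the scatter). This position therefore takes the larger neopentyl group without a change beyond the scatter. Nothing available explains this result. Going by these compounds, whether a longer chain, an amine or a carboxylic acid at this position would also stay within the scatter remains open, as does the outcome of the same change on the core of compound 2.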